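Moving the Chlorine on the Benzoyl Ring of an Aminothiophene

The compounds below may be only part of what the source reports. "The series", "measured", "known", "first", "only" and "open" are said of these compounds alone.

Compound 1: `CC(C)(C)Cc1csc(N)c1C(=O)c1ccc(Cl)cc1` — 1%
Compound 2: `CC(C)(C)Cc1c(-c2ccccc2)sc(N)c1C(=O)c1ccc(Cl)cc1` — 1%

In an assay on CHO cells for displacement of a labelled ligand from adenosine receptor A1 (Homo sapiens), read by scintillation counting, tested at 10 uM (on this read-out lower numbers stand for less inhibition and higher numbers for more inhibition at the one concentration tested (going by the name of the read-out)), compound 1 gives 1%, and compound 2 gives 1%. Going by the values given here, the one measured step, no change at the digits printed from compound 1 to compound 2 (within the scatter), shows nothing beyond the scatter. Compound 2 therefore stands level with compound 1, with no sign of inhibition in this assay.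

Compound 3 is `CC(C)(C)Cc1c(-c2ccccc2)sc(N)c1C(=O)c1ccccc1Cl`. It differs from compound 2 by 2-chlorophenyl in place of 4-chlorophenyl on a carbonyl carbon. Among the compounds with values here, no measured step touches this part of the molecule, so the only guide is that compound 2 itself sits at the floor of the read-out. Compound 3 is expected to stay there, with a step of a number 1 percentage points higher from compound 2 to compound 3 (within the scatter), giving an estimate of 2% (range -8% to 12%).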

Compound 3, a percentage reported as inhibition, at one concentration (the size of the read-out at that concentration, not a potency): 1%
Beside the measured number, compound 3's estimate is 1 percentage points above it; measured number inside the range.
By their numbers in this assay, from the lowest: compounds 1, 2 and 3 (each within the scatter of the next).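

Moving from 4-chlorophenyl to 2-chlorophenyl on the carbonyl carbon gives no change at the digits printed from compound 2 to compound 3 (within the scatter) in this assay. This is the first measured change at this part of the molecule, and it shows that, among these two compounds, where the chlorine stands on this ring makes no difference to the read-out, which stays at the floor. No evidence at hand bears on this result.

The compounds shown leave open whether an amine or a carboxylic acid in place of the chlorine would give any measurable inhibition in this assay at all.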